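Propargyl to 4-bromobenzyl in the growth inhibition series

The source may hold more compounds than are shown below. What is called first, only, known or untested is meant among the compounds shown, and "the series" means these compounds.

Compound 1 `C=C(C)C(=O)N(Cc1ccccc1C)C(=O)/C=C/c1cc(OC)c(OC)c(OC)c1`: > 10000 nM (a limit)
Compound 2 `C#CCN(C(=O)/C=C/c1cc(OC)c(OC)c(OC)c1)C(=O)C(=C)C`: 7300 nM
Compound 3 `C=C(C)C(=O)N(Cc1ccc(Br)cc1)C(=O)/C=C/c1cc(OC)c(OC)c(OC)c1`: not yet measured

For the measured compounds named here, in a functional assay on PC-3 cells (Homo sapiens) for inhibition, read by WST assay, with a stated time of 48 h (on this read-out lower numbers stand for stronger inhibition of growth and higher numbers for weaker inhibition of growth), compound 2 gives 7300 nM, the only true number so far. Compound 1 stays at a limit: the limit of > 10000 nM in this assay, at which 1 of the 2 values shown sits.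

Compound 3 changes one group on a saturated chain carbon bound to an amide-type nitrogen: 4-bromophenyl in place of ethynyl on a saturated chain carbon bound to an amide-type nitrogen. Going by the values given here, the one measured step at this place is an at least 1.3-fold lower number from compound 1 to compound 2 (0.13 log units; that floor lies within the scatter). That step put ethynyl in place of 2-methylphenyl, and compound 3 returns a substituted phenyl to the same place. Among the compounds with values here, with only this floor as a guide, a small move towards a higher number in this assay is expected, perhaps none beyond the scatter. The expected change is a 1.4-fold higher number from compound 2 to compound 3 (0.14 log units; within the scatter). A reading at the limit would not be a surprise. For compound 3 the estimate is 10000 nM, with an expected range of 3500 nM to 30000 nM.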

Compound 3, concentration for 50% growth inhibition: > 10000 nM
Compound 3 ended at the assay's limit (the forecaster's own chance of this, stated with the estimate: 50%); the middle value lies on the limit itself.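

In this assay, the second substituted phenyl at this place on a saturated chain carbon bound to an amide-type nitrogen gives an at least 1.3-fold higher number from compound 2 to compound 3 (0.13 log units; that floor lies within the scatter), so the data still do not separate ethynyl from 4-bromophenyl. Moving the substituent and changing it from 2-methylphenyl to 4-bromophenyl yields no true number, and the step between compound 1 and compound 3 cannot be read, as both are limits. Both compounds with a substituted phenyl here now sit at a limit, and only compound 2, with ethynyl, has a true number: the limit of > 10000 nM in this assay, at which 2 of the 3 values shown sit.

Going by these compounds, how far compound 1 and compound 3 lie from compound 2 remains unknown. Also open, on these data alone, is whether an amine or a carboxylic acid on the phenyl, or a longer chain in place of ethynyl, would give a true number at this place.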